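From tert-Butyl to Chloro: Estimating the Growth Inhibition of Compound 4

A few compounds are considered here, and "the series" means these few. Any claim that something is new, unique, unknown or untested is made for them only; others in the source may bear on it.

Compound 3 `CC(C)(C)c1ccc(-c2cc(N3CCC(CCNS(N)(=O)=O)CC3)ncn2)cc1` gives the lowest number of the three in a functional assay on MCF7 cells (Homo sapiens) for antiproliferative activity, read by sulforhodamine B assay, with a stated time of 48 h (a higher number here means a weaker inhibitor of growth, a lower number a stronger inhibitor of growth), at 13100 nM. Compound 1 `NS(=O)(=O)NCC1CCN(c2cc(-c3ccc(Cl)cc3)ncn2)CC1` gives 25500 nM, within the scatter of compound 3, while compound 2 `Cc1ccc(-c2cc(N3CCC(CCNS(N)(=O)=O)CC3)ncn2)cc1` gives 47500 nM, and the step from compound 2 to compound 3 was a 3.6-fold lower number from compound 2 to compound 3 (0.56 log units; beyond the scatter). Compound 4 `NS(=O)(=O)NCCC1CCN(c2cc(-c3ccc(Cl)cc3)ncn2)CC1` differs from compound 3 by chloro in place of tert-butyl on an aromatic carbon. Within the data shown here, the only comparable change is that methyl-to-tert-butyl step, which suggests the tert-butyl group favours potency; compound 1, which also carries chloro, sits near compound 3. A modest rise in the number is therefore expected, a 1.7-fold higher number from compound 3 to compound 4 (0.23 log units; within the scatter), giving an estimated value for compound 4 of 22000 nM, with a likely range of 10000 nM to 50000 nM.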

Compound 4, concentration for 50% growth inhibition: 19700 nM
Compound 4: the middle estimate sits 1.1-fold (0.05 log units) above what was measured; measured number inside the range.
By their numbers in this assay, from the lowest: compounds 3, 4, 1 and 2 (each within the scatter of the next, the first and the last beyond it).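

In this assay, tert-butyl and chloro on this aromatic carbon cannot be told apart, with a 1.5-fold higher number from compound 3 to compound 4 (0.18 log units; within the scatter). Chloro in place of methyl gives a 2.4-fold lower number from compound 2 to compound 4 (0.38 log units; beyond the scatter), so at this position a large group is not required to move beyond methyl, as chloro has only one heavy atom. The chain change also stays within the scatter, with a 1.3-fold lower number from compound 1 to compound 4 (0.11 log units; within the scatter).

No measurement available here explains these differences. On these data alone, whether a methoxy group, an amine or a carboxylic acid on this aromatic carbon would match chloro remains open.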